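The compounds below may be only part of what the source reports. "The series", "measured", "known", "first", "only" and "open" are said of these compounds alone.

Compound 1 `Cc1ccc2occ(C3N=C(c4ccccc4)SS3)c(=O)c2c1` — 32%
Compound 2 `O=c1c(C(=S)Nc2ccccc2)coc2cc(Cl)ccc12` — 38%
Compound 3 `O=c1c(C2N=C(c3ccccc3)SS2)coc2cc(Cl)c(Cl)cc12` — 50%

Of the compounds shown here, three sharing the same core have been measured. In a functional assay on COLO 205 cells (Homo sapiens) for inhibition, read by sulforhodamine B assay, with a stated time of 48 h, tested at 100 uM (a higher number here means more inhibition of growth at the concentration tested, a lower number less inhibition of growth), compound 1 gives 32%, the lowest of the three numbers. Compound 2 gives 38%, a number that lies within the usual scatter of the value of compound 1, so no order between these two can be read. Compound 3 gives 50%, a number beyond the scatter above compound 1; compound 3 carries two chloro groups and differs from compound 1 in more than one place, so only its value, not a single step, can be taken from it.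

Compound 4 `O=c1c(C2N=C(c3ccccc3)SS2)coc2ccc(F)cc12` is the next compound to be measured in this assay. It differs from compound 1 in one place: fluoro in place of methyl on an aromatic carbon. Within the data shown here, no pair of measured compounds differs in one place, so there is no measured step of this kind to set the size. On the numbers available the expected change is small, a step from compound 1 to compound 4 of a number 4 percentage points higher from compound 1 to compound 4 (within the scatter), within the scatter, with no clear direction. For compound 4 the estimated value in this assay is 36%, expected to fall between 22% and 52%.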

Compound 4, percent growth inhibition at one concentration: 37%
Compound 4: the middle estimate sits 1 percentage points below what was measured; the range from low to high includes it.
By their numbers in this assay, from the lowest: compounds 1, 4 and 2 (each within the scatter of the next); then compound 3.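

In this assay, among these compounds, fluoro in place of methyl on an aromatic carbon of the six-membered aromatic ring gives a number 5 percentage points higher from compound 1 to compound 4 (within the scatter), the first step in this set that isolates a change in one place. At this position the two groups therefore cannot be told apart by percent growth inhibition, and the modest inhibition seen with compound 1 does not rest on the methyl group alone, as compound 4 retains a value within the scatter of it. Nothing available explains this outcome or shows what either group contributes at this position.

The compounds shown leave open whether a different kind of group on this carbon, such as an amine, a carboxylic acid or a longer chain, would move the number beyond the scatter, since methyl and fluoro are each a single heavy atom. No single step yet connects compound 3, with its chloro groups, to the other compounds, so which of its structural differences accounts for its value also remains unresolved.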